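Furan-2-yl in place of phenyl on compound 2

The source may hold more compounds than are shown below. What is called first, only, known or untested is meant among the compounds shown, and "the series" means these compounds.

In an ADME assay on SH-SY5Y cells (Homo sapiens) for cytotoxicity, read by MTT assay, with a stated time of 72 h (a lower number here means that less compound is tolerated, a higher number that more compound is tolerated), compound 1 `c1ccc(-c2cn3cc(-c4ccco4)ccc3n2)cc1` gives > 100000 nM which is a limit and not a number. Compound 2 `Nc1cc(-c2ccco2)cn2cc(-c3ccccc3)nc12` gives 26000 nM and compound 3 `COc1ccc(-c2cn3cc(-c4ccco4)cc(N)c3n2)cc1OC` gives 36400 nM so these two stand within the scatter of each other. For the measured compounds named here, the one measured step is an at least 3.8-fold lower number from compound 1 to compound 2 (0.58 log units; beyond the scatter) with amino in place of hydrogen on an aromatic carbon, and it starts from a limit and leaves the phenyl untouched. Going by the values given here, compound 4 `Nc1cc(-c2ccco2)cn2cc(-c3ccco3)nc12` carries furan-2-yl in place of phenyl on an aromatic carbon and no measured step makes this exchange. So from compound 2 at 26000 nM the step to the new compound is expected to stay within the scatter in this assay. The estimate means a 1.2-fold higher number from compound 2 to compound 4 (0.09 log units; within the scatter) as the expected step. Compound 4 is expected at 32000 nM with an estimated range of 14000 nM to 80000 nM in this measurement.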

Compound 4, half-maximal cytotoxic concentration: 2270 nM
Compound 4: middle estimate off by 14-fold (1.15 log units), on the high side; measured number outside the range, below it.
By their numbers in this assay, from the lowest: compound 4; then compounds 2 and 3 (each within the scatter of the next). At a limit, above all of these: compound 1.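

Until compound 4, every compound shown held a six-membered aromatic ring of carbon only at this place, on the five-membered aromatic ring with 2 nitrogen. Furan-2-yl in place of phenyl there gives an 11-fold lower number from compound 2 to compound 4 (1.06 log units; beyond the scatter) in this assay, so this place, and not only the amino group, bears on how much compound is tolerated. Nothing given here accounts for the step.

Going by these compounds, whether thiophen-2-yl, pyridin-2-yl or a methyl at this place would give a similar number remains open. So does whether the same exchange would count for as much without the amino group.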